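Four-Membered Ring in Place of the Carbamoylethyl Chain

The compounds below may be only part of what the source reports. "The series", "measured", "known", "first", "only" and "open" are said of these compounds alone.

Compound 3 `NC(=O)CCn1cc(-c2ccc3cc[nH]c3c2)c(C(F)(F)F)n1` carries a 2-carbamoylethyl group on an aromatic nitrogen. In an assay on isolated protein for inhibition of thyroid peroxidase (Homo sapiens) (a higher number here means a weaker inhibitor, a lower number a stronger inhibitor), compound 3 gives only the limit > 30000 nM. Compound 1 `NCc1ccc(-n2cc(-c3ccc4cc[nH]c4c3)c(C(F)(F)F)n2)cc1` likewise gives only a limit, > 30000 nM, in this assay. Compound 2 `FC(F)(F)c1nn(-c2ccc(Cc3nc[nH]n3)cc2)cc1-c1ccc2cc[nH]c2c1` gives 5900 nM, and an at least 5.0-fold lower number from compound 1 to compound 2 (0.70 log units; beyond the scatter). The other step, a step that the two limits leave unreadable from compound 1 to compound 3, is not readable. Compound 4 `NC[C@H]1C[C@H](n2cc(-c3ccc4cc[nH]c4c3)c(C(F)(F)F)n2)C1` differs from compound 3 in one place: a group of 6 heavy atoms (5 carbon, 1 nitrogen; one four-membered non-aromatic ring of carbon only) in place of a group of 5 heavy atoms (3 carbon, 1 nitrogen, 1 oxygen; no ring), on an aromatic nitrogen. Among the compounds with values here, no measured step exchanges the group on this nitrogen between two readable numbers, and the limit of > 30000 nM in this assay, at which 2 of the 3 values shown sit, leaves compound 3 without a number to move from, so a further limit is the likeliest outcome. Compound 4 is expected to give about 30000 nM, between 8000 nM and 100000 nM, an estimated step of a number no higher from compound 3 to compound 4 (the limit leaves the size open).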

Compound 4, half-maximal inhibitory concentration: > 30000 nM
Compound 4: a limit, no number (the forecaster's own chance of this, stated with the estimate: 60%); the middle value sits exactly at the limit.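

In this assay compound 4 gives only a limit, > 30000 nM, and the steps to it from compound 3 and from compound 1 cannot be read. The compounds shown leave open how far the four-membered ring group, 2-carbamoylethyl and 4-(aminomethyl)phenyl differ on this aromatic nitrogen.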